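A Chlorofuran Exchange at an Untested Place

The source may hold more compounds than are shown below. What is called first, only, known or untested is meant among the compounds shown, and "the series" means these compounds.

In a functional assay on HeLa cells (Homo sapiens) for cytotoxicity, read by ELISA, with a stated time of 4 days (a lower number here means a stronger inhibitor, a higher number a weaker inhibitor), compound 1 (`Clc1ccc(-c2cc(-c3ccoc3)cc(-c3ccco3)n2)s1`) gives 22700 nM as its reading, compound 2 (`Cc1ccccc1-c1cc(-c2ccoc2)cc(-c2ccc(Cl)s2)n1`) gives 19000 nM as its reading, and compound 3 (`Clc1ccc(-c2cc(-c3ccoc3)cc(-c3ccc(Cl)s3)n2)cc1`) gives 16500 nM as its reading. Compound 1 thus stands level with both of the others: a 1.2-fold lower number from compound 1 to compound 2 (0.08 log units; within the scatter) and a 1.4-fold lower number from compound 1 to compound 3 (0.14 log units; within the scatter) are the steps that separate them, and a 1.2-fold lower number from compound 2 to compound 3 (0.06 log units; within the scatter) completes the set.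

Compound 4 (`Clc1ccc(-c2cc(-c3ccco3)nc(-c3ccc(Cl)s3)c2)o1`) differs from compound 1 in one place, with 5-chlorofuran-2-yl in place of furan-3-yl on an aromatic carbon opposite the ring nitrogen (5-chlorofuran-2-yl in place of furan-3-yl on an aromatic carbon). Among the measured compounds shown here, no measured step touches that place, so the evidence is indirect. At another place on the core, the exchange of furan-2-yl for 2-methylphenyl gave a 1.2-fold lower number from compound 1 to compound 2 (0.08 log units; within the scatter) and the exchange for 4-chlorophenyl gave a 1.4-fold lower number from compound 1 to compound 3 (0.14 log units; within the scatter) without leaving the scatter. On that limited basis, no step beyond the scatter is expected in this assay, though the untested place keeps the range wide. The expected step is a 1.4-fold lower number from compound 1 to compound 4 (0.15 log units; within the scatter) and no more than a tentative lean in direction. For compound 4 the estimated value is 16000 nM in this assay. The expected range for compound 4 runs from 6000 nM to 40000 nM for now.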

Compound 4, half-maximal inhibitory concentration: > 50000 nM
Compound 4 gave a limit, no number; the forecaster's own chance of this, stated with the estimate: 10%; middle value at least 3.1-fold (0.49 log units) away from the limit.
By their numbers in this assay, from the lowest: compounds 3, 2 and 1 (each within the scatter of the next). At a limit, above all of these: compound 4.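

In this assay compound 4 gives no number but a limit of the assay: the limit of > 50000 nM in this assay, at which 1 of the 4 values shown sits. Among the compounds shown here, the exchange of furan-3-yl for 5-chlorofuran-2-yl on the aromatic carbon opposite the ring nitrogen gave an at least 2.2-fold higher number from compound 1 to compound 4 (0.34 log units; beyond the scatter), the only step in the set that lies beyond the scatter, and it points towards a weaker inhibitor. For the compounds shown here, the earlier steps, all at another place on the shared core, stayed within the scatter, so this result is the first sign that the readings are not indifferent to what stands opposite the ring nitrogen.

The entering group differs from the leaving one both in its chlorine and in the ring carbon through which the furan is attached, and the compounds shown cannot separate these two changes. They also leave open how the place opposite the ring nitrogen would respond to an unchlorinated furan-2-yl group, or to a group of another kind, such as an amine or a carboxylic acid.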